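This account rests on a few compounds, and the source may have more. Where it says the series, first, only, none or still open, it means among the compounds named here.

Measured in an assay on LM cells for displacement of a labelled ligand from Neuropeptide Y receptor type 5 (Homo sapiens); a lower number here means a stronger inhibitor, a higher number a weaker inhibitor:
compound 1 `Fc1ccc(C2(c3ccc(F)cc3)CNC(c3cccc(Cl)c3)=N2)cc1` gives 5.4 nM
compound 2 `O=Cc1cccc(C2=NC(c3ccc(F)cc3)(c3ccc(F)cc3)CN2)c1` gives 8.7 nM
compound 3 `CC(=O)c1cccc(C2=NC(c3ccc(F)cc3)(c3ccc(F)cc3)CN2)c1` gives 44 nM

Compound 3 has the highest number of the three: a 5.1-fold higher number from compound 2 to compound 3 (0.70 log units; beyond the scatter) and an 8.1-fold higher number from compound 1 to compound 3 (0.91 log units; beyond the scatter), both beyond the scatter, so it is the weakest inhibitor shown. Compound 4 `CN(C)c1cccc(C2=NC(c3ccc(F)cc3)(c3ccc(F)cc3)CN2)c1` carries the change (dimethylamino in place of acetyl on an aromatic carbon). Within the data shown here, no measured step puts dimethylamino on this carbon; the steps that bear on the move are those that introduced acetyl, an 8.1-fold higher number from compound 1 to compound 3 (0.91 log units; beyond the scatter) and a 5.1-fold higher number from compound 2 to compound 3 (0.70 log units; beyond the scatter), which show acetyl as the least favourable group tried, while a 1.6-fold higher number from compound 1 to compound 2 (0.21 log units; within the scatter) stays within the scatter. Removing acetyl is therefore expected to give a modest drop in this assay, a 3.7-fold lower number from compound 3 to compound 4 (0.56 log units; beyond the scatter), the entering group being untested. Compound 4 is estimated at 12 nM, range 3 nM to 50 nM.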

Compound 4, half-maximal inhibitory concentration: > 1000 nM
Compound 4 was reported as a limit (the forecaster's own chance of this, stated with the estimate: 3%); middle value at least 83-fold (1.92 log units) away from the limit.
By their numbers in this assay, from the lowest: compounds 1 and 2 (each within the scatter of the next); then compound 3. At a limit, above all of these: compound 4.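

In this assay this aromatic carbon proves far less tolerant than compounds 1 to 3 suggested: dimethylamino in place of acetyl, with the same count of heavy atoms, gives a large loss (an at least 22-fold higher number from compound 3 to compound 4 (1.35 log units; beyond the scatter)). The gaps from formyl (an at least 110-fold higher number from compound 2 to compound 4 (2.06 log units; beyond the scatter)) and chloro (an at least 180-fold higher number from compound 1 to compound 4 (2.26 log units; beyond the scatter)) are larger still. Compound 4 gives > 1000 nM which is a limit and not a number.

From the compounds shown here alone, how far compound 4 lies past that limit stays open. Also open, going by these compounds, is whether the loss extends to a primary amine or a methoxy group on this carbon.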